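This account rests on a few compounds, and the source may have more. Where it says the series, first, only, none or still open, it means among the compounds named here.

In a functional assay on the whole organism for antagonist activity, with Mus musculus as the target (on this read-out higher numbers stand for an effect only at larger amounts of compound and lower numbers for an effect already at smaller amounts), compound 1 `CCOC(=O)N(C)C(C)C#CCN1CCCC1` gives > 100 mg/kg, which is a limit of the assay and not a number. Compound 2 `O=C1NCCN1CC#CCn1ccnc1` gives > 100 mg/kg, which is also a limit. Within the data shown here, compound 3 `Cc1cncn1CC#CCN1CCNC1=O` gives 66 mg/kg, the only actual number so far. Compound 4 `Cc1cncn1CC#CCN1CCN(C)C1=O` differs from compound 3 by one change: methyl in place of hydrogen on an amide-type nitrogen in a ring. Among the measured compounds shown here, one measured step bears on this change, an at least 1.5-fold lower number from compound 2 to compound 3 (0.18 log units; that floor lies within the scatter). It also puts methyl in place of hydrogen, but on an aromatic carbon rather than on an amide-type nitrogen in a ring. It therefore offers only a weak guide, and no shift beyond the scatter is expected in either direction in this assay. The expected step is a 1.1-fold higher number from compound 3 to compound 4 (0.03 log units; within the scatter). For compound 4 the estimate is 70 mg/kg, with an expected range from 30 mg/kg to 165 mg/kg.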

Compound 4, dose for half-maximal effect: > 100 mg/kg
Compound 4 gave a limit, no number (the forecaster's own chance of this, stated with the estimate: 35%); middle value at least 1.4-fold (0.15 log units) from the limit.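

On this amide-type nitrogen in a ring, the amide hydrogen of compound 3 is the only group shown that goes with an actual number. In this assay, methyl in its place gives an at least 1.5-fold higher number from compound 3 to compound 4 (0.18 log units; that floor lies within the scatter). That floor does not settle whether the change matters, because the true size of the step is hidden at the limit of the read-out: the limit of > 100 mg/kg in this assay, at which 3 of the 4 values shown sit.

On these data alone, how far compound 4 really lies from compound 3 stays open. So does whether ethyl or a longer chain on this nitrogen would give a number at all.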